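Exchanging 5-methyl-1,2-oxazol-4-yl for 5-methyl-1,3-oxazol-2-yl

The source may hold more compounds than are shown below. What is called first, only, known or untested is meant among the compounds shown, and "the series" means these compounds.

For the measured compounds named here, compound 1 `COc1c(OCc2cnoc2C)cc(O)c2c(=O)cc(-c3ccccc3)oc12` is the only compound in this small set with a reported result in a functional assay on A549 cells (Homo sapiens) for cytotoxicity, read by MTT assay, with a stated time of 48 h; a higher number here means a weaker inhibitor, a lower number a stronger inhibitor. In this assay compound 1 gives > 100000 nM, which is a limit of the assay and not a number. Compound 2 `CCCCNCCCCOc1c(O)cc(O)c2c(=O)cc(-c3ccccc3)oc12` offers no comparison, with "not determined" (no result reported). Compound 3 `CC(C)NCCOc1c(O)cc(O)c2c(=O)cc(-c3ccccc3)oc12` likewise has "not determined" (no result reported).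

Compound 4 `COc1c(OCc2ncc(C)o2)cc(O)c2c(=O)cc(-c3ccccc3)oc12` has the same atoms as compound 1, joined differently: 5-methyl-1,3-oxazol-2-yl stands in place of 5-methyl-1,2-oxazol-4-yl on a saturated chain carbon bound to an oxygen on an aromatic ring (5-methyl-1,3-oxazol-2-yl in place of 5-methyl-1,2-oxazol-4-yl on a saturated chain carbon bound to an oxygen on an aromatic ring). Going by the values given here, no measured pair shows what such an exchange does in this assay, so no step beyond the scatter is expected, in either direction. This expectation rests on compound 1 alone, with the limit of > 100000 nM in this assay, at which 1 of the 3 values shown sits. The estimated change is a number no higher from compound 1 to compound 4 (the limit leaves the size open), and the assay may well again report only a limit. For compound 4 the expected value is 100000 nM, with an estimated range from 30000 nM to 200000 nM.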

Compound 4, half-maximal inhibitory concentration: > 100000 nM
Compound 4 gave a limit, no number; the forecaster's own chance of this, stated with the estimate: 65%; the middle value lies on the limit itself.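

For the compounds shown here, compound 4, like compound 1, returns only a limit of the assay in this assay, and no step between the two can be read. The compounds shown leave open what exchanging these two rings does in any compound that gives a measurable number.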